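The source may hold more compounds than are shown below. What is called first, only, known or untested is meant among the compounds shown, and "the series" means these compounds.

Compound 1 `O=C(Nc1nc2ccc(Cl)cc2s1)c1cc(-c2ccc(F)cc2)n2nc(-c3ccccc3)cc2n1` gives 6600 nM in a functional assay on A549 cells (Homo sapiens) for cytotoxicity, read by MTT assay, with a stated time of 48 h; a lower number here means a stronger inhibitor, a higher number a weaker inhibitor.
Compound 2 `COc1ccc(-c2cc(C(=O)Nc3nc4ccc(Cl)cc4s3)nc3cc(-c4ccccc4)nn23)cc1` gives 3090 nM in this assay.
Compound 3 `COc1cc(-c2cc(C(=O)Nc3nc4ccc(Cl)cc4s3)nc3cc(-c4ccccc4)nn23)cc(OC)c1OC` gives 18200 nM in this assay.

Compound 1 stands second highest of these three numbers: there is a 2.1-fold lower number from compound 1 to compound 2 (0.33 log units; beyond the scatter), and a 2.8-fold higher number from compound 1 to compound 3 (0.44 log units; beyond the scatter). Compound 4 `O=C(Nc1nc2ccc(F)cc2s1)c1cc(-c2ccc(F)cc2)n2nc(-c3ccccc3)cc2n1` differs from compound 1 by fluoro in place of chloro on an aromatic carbon. For the measured compounds named here, every measured step so far, including a 5.9-fold higher number from compound 2 to compound 3 (0.77 log units; beyond the scatter), alters the 4-fluorophenyl end of the shared core, not the benzothiazole end, so no measured step bears directly on this exchange. Swapping one halogen for another at the same place is a small change, so the expected outcome is a step from compound 1 to compound 4 of a 1.1-fold higher number from compound 1 to compound 4 (0.03 log units; within the scatter), within the scatter. Compound 4 is therefore estimated at 7000 nM in this assay, with a range from 3000 nM to 16000 nM.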

Compound 4, half-maximal inhibitory concentration: 14800 nM
For compound 4 the middle estimate is 2.1-fold (0.33 log units) below the measured one; the range from low to high includes it.
By their numbers in this assay, from the lowest: compound 2; then compound 1; then compounds 4 and 3 (each within the scatter of the next).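

For the compounds shown here, compound 4 gives the first reading at the 6-chloro-1,3-benzothiazol-2-yl end of the shared core: in this assay there is a 2.2-fold higher number from compound 1 to compound 4 (0.35 log units; beyond the scatter) for this exchange. So even replacing one halogen with another at this place moves the number beyond the scatter, and fluoro gives the weaker inhibitor of this pair. Nothing shown here explains the size of this step.

Only chloro and fluoro are shown at this place, so the effect of bromo or an amine there stays open. From the compounds shown here alone, it is also open whether this step would carry over to the 4-methoxyphenyl compound 2.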